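The source may hold more compounds than are shown below. What is called first, only, known or untested is meant among the compounds shown, and "the series" means these compounds.

Of the compounds shown here, three sharing one core have been measured in a functional assay on CHO cells for inhibition of metabotropic glutamate receptor 5 (Rattus norvegicus), read by FLIPR and calcium flux; on this read-out higher numbers stand for weaker inhibition and lower numbers for stronger inhibition. Compound 1 `Cc1ccc2ccc(-c3cccc(C#N)c3)cc2n1` gives 7.7 nM, compound 2 `COc1cccc(-c2ccc3ccc(C)nc3c2)c1` gives 860 nM, and compound 3 `Cc1ccc2ccc(-c3cccc(Cl)c3)cc2n1` gives 14000 nM, the highest number of the three. The steps of a 110-fold higher number from compound 1 to compound 2 (2.05 log units; beyond the scatter), a 16-fold higher number from compound 2 to compound 3 (1.21 log units; beyond the scatter) and a 1800-fold higher number from compound 1 to compound 3 (3.26 log units; beyond the scatter) all lie beyond the scatter. Compound 4 `Cc1ccc2ccc(-c3cccc(OC(F)(F)F)c3)cc2n1` carries trifluoromethoxy in place of chloro on an aromatic carbon, placed meta to a large group. Among the compounds with values here, no measured step involves a trifluoromethoxy group, so the only guide is that changing the substituent at this position has already moved the number widely across compound 1, compound 2 and compound 3. The expected step is a 4.7-fold lower number from compound 3 to compound 4 (0.67 log units; beyond the scatter), toward a lower number, of uncertain size. The estimate for compound 4 is 3000 nM, within 400 nM to 20000 nM.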

Compound 4, half-maximal inhibitory concentration: > 10000 nM
Compound 4 gave a limit, no number; the forecaster's own chance of this, stated with the estimate: 5%; at least 3.3-fold (0.52 log units) between middle value and limit.
By their numbers in this assay, from the lowest: compound 1; then compound 2; then compound 3.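

Compound 4 gives > 10000 nM, which is a limit of the assay and not a number. Replacing the methyl on the oxygen of compound 2 with trifluoromethyl gives an at least 11-fold higher number from compound 2 to compound 4 (1.06 log units; beyond the scatter), and trifluoromethoxy in place of the nitrile gives an at least 1200-fold higher number from compound 1 to compound 4 (3.11 log units; beyond the scatter), so this position now holds a second group that falls far short of the nitrile. The step from compound 3 cannot be read, which leaves chloro and trifluoromethoxy unordered.

On these data alone, what remains open is how far compound 4 lies past its limit. As far as these compounds go, it is also open whether an amine, an amide or a carboxylic acid at this position would come close to compound 1.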